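Swapping a para-ethyl for a para-chloro on the sulfonamide aniline

The source may hold more compounds than are shown below. What is called first, only, known or untested is meant among the compounds shown, and "the series" means these compounds.

Measured compounds:
- Compound 1, `CCc1ccccc1NS(=O)(=O)c1ccc(N2CCNC2=O)cc1`: 240 nM
- Compound 2, `O=C1NCCN1c1ccc(S(=O)(=O)Nc2ccc3[nH]ccc3c2)cc1`: 130 nM
- Compound 3, `CCc1ccc(NS(=O)(=O)c2ccc(N3CCNC3=O)cc2)cc1`: 660 nM

All three share a core in which a cyclic urea is attached to a benzenesulfonamide, and they differ only in the aromatic group carried on the sulfonamide nitrogen. In a functional assay on HT-29 cells (Homo sapiens) for antiproliferative activity, read by sulforhodamine B assay, with a stated time of 48 h (on this read-out higher numbers stand for weaker inhibition and lower numbers for stronger inhibition), compound 3 gives the highest number of the three, so it is the weakest inhibitor in this set; compound 1 sits closest to it, and compound 2 is furthest away with the lowest number. Among the measured compounds shown here, the one step that can be compared directly, a 2.8-fold higher number from compound 1 to compound 3 (0.44 log units; beyond the scatter), shows that moving the ethyl group from one ring position to another already shifts the result beyond the scatter.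

Compound 4, `O=C1NCCN1c1ccc(S(=O)(=O)Nc2ccc(Cl)cc2)cc1`, keeps the 4-substituted pattern of compound 3 but changes the substituent itself: chloro in place of ethyl on an aromatic carbon. For the measured compounds named here, no measured step here replaces one substituent by another at the same ring position, so the direction of this change cannot be read from the data; only the ring-position step for compound 1 and compound 3 gives a sense of scale. A step of a 1.3-fold lower number from compound 3 to compound 4 (0.12 log units; within the scatter) is therefore expected, meaning compound 4 is estimated at 500 nM, between 200 nM and 1500 nM.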

Compound 4, half-maximal inhibitory concentration: 220 nM
Beside the measured number, compound 4's estimate is 2.3-fold (0.36 log units) above it; low and high end bracket the measured number.
By their numbers in this assay, from the lowest: compounds 2, 4 and 1 (each within the scatter of the next); then compound 3.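

Among the compounds shown here, this is the first step that changes the group itself while the ring position stays fixed, on an aromatic carbon para to a large group. In this assay, the result is a 3.0-fold lower number from compound 3 to compound 4 (0.48 log units; beyond the scatter), so the identity of the group at this place matters as well as its ring position, even though neither ethyl nor chloro carries a hydrogen-bond donor or acceptor. The other comparison, a 1.1-fold lower number from compound 1 to compound 4 (0.04 log units; within the scatter), places the 4-chlorophenyl and 2-ethylphenyl compounds within the scatter of each other, so the weaker result of compound 3 belongs to the 4-ethylphenyl group and not to every group at that ring position. Nothing available explains why chloro and ethyl differ here; the numbers give only the size of the change.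

As far as these compounds go, with just these two groups at this place, it remains open whether the trend would hold for a fluoro, a methoxy or a longer chain such as propyl, or for a group of a different kind, such as an amine or a carboxylic acid. From the compounds shown here alone, it is also open whether chloro would behave the same way at the ring position that ethyl holds in compound 1.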